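Series notes: hexyl replaced by 4-nitrophenyl on the chain

The compounds below may be only part of what the source reports. "The series", "measured", "known", "first", "only" and "open" are said of these compounds alone.

Measured so far in a functional assay on HeLa cells (Homo sapiens) for cytotoxicity, read by WST assay, with a stated time of 48 h; a higher number here means a weaker inhibitor, a lower number a stronger inhibitor:
- compound 1, `CCCCCC/C=C/C[C@H]1C[C@@H]([C@@H](O)c2ccccc2)CO[C@@H]1c1ccccc1`: 7400 nM
- compound 2, `COc1ccc(/C=C/C[C@H]2C[C@@H]([C@@H](O)c3ccc(OC)c(OC)c3)CO[C@@H]2c2ccc(OC)c(OC)c2)cc1`: 12200 nM
- compound 3, `COc1ccc([C@H]2OC[C@H]([C@@H](O)c3ccc(OC)c(OC)c3)C[C@@H]2C/C=C/c2ccccc2)cc1OC`: 14800 nM

Compound 1 gives the lowest of the three numbers in this assay, but its gaps to compound 2 and to compound 3 both lie within the scatter, so no order among the three can be read from the values. For the measured compounds named here, the single step between measured compounds, a 1.2-fold higher number from compound 2 to compound 3 (0.08 log units; within the scatter), is also within the scatter.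

Compound 4, `O=[N+]([O-])c1ccc(/C=C/C[C@H]2C[C@@H]([C@@H](O)c3ccccc3)CO[C@@H]2c2ccccc2)cc1`, is not yet measured. It differs from compound 1 by 4-nitrophenyl in place of hexyl on a double-bonded chain carbon bound to a double-bonded chain carbon. Going by the values given here, no measured step touches this position directly; compounds 2 and 3 carry a six-membered aromatic ring where compound 1 carries hexyl, and their numbers sit within the scatter of compound 1. The change is therefore expected to give no step beyond the scatter, with a slight lean toward a higher number, a 1.3-fold higher number from compound 1 to compound 4 (0.11 log units; within the scatter). Compound 4 is estimated at 9500 nM, in a range from 4000 nM to 22000 nM.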

Compound 4, half-maximal inhibitory concentration: 12400 nM
Compound 4: middle estimate off by 1.3-fold (0.12 log units), on the low side, and the stated range covers the measured number.
By their numbers in this assay, from the lowest: compounds 1, 2, 4 and 3 (each within the scatter of the next).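

In this assay, for the compounds shown here, the step of a 1.7-fold higher number from compound 1 to compound 4 (0.22 log units; within the scatter) is the first reading of this position with the rest of the structure held fixed, since the earlier compounds with an aromatic ring on the chain also carry methoxy groups elsewhere. On the core of compound 1, 4-nitrophenyl in place of hexyl on a double-bonded chain carbon bound to a double-bonded chain carbon leaves the number within the scatter, so this exchange of a saturated chain for a nitro-bearing aromatic ring gives no readable change here. Nothing at hand explains this result.

Still open, on these data alone, is whether a plain phenyl on the same core would also stay within the scatter, which would separate the ring from the nitro group. Also open, as far as these compounds go, is whether an amine, a carboxylic acid or a longer chain at this place would give a step beyond the scatter.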